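Swapping the thiazole amide of compound 1 for a larger ring

A few compounds are considered here, and "the series" means these few. Any claim that something is new, unique, unknown or untested is made for them only; others in the source may bear on it.

In a functional assay on the whole organism (blood) with Rattus norvegicus as the target, with stated times of 24 h and 1 h, at a dose of 15 mg/kg by the intraperitoneal route (a lower number here means a weaker effect, a higher number a stronger effect of the compound at the dose given), three compounds have been measured so far:
Compound 1, `Cc1ncsc1C(=O)NCCC1CCN(S(=O)(=O)NC(=O)NC[C@@H]2C[C@@H]3C=C[C@@H]2C3)CC1`, gives 25%.
Compound 2, `O=C(NC1CCCCC1)NS(=O)(=O)N1CCC(CCNC(=O)c2nsc3ccccc23)CC1`, gives 17%.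
Compound 3, `O=C(NC[C@@H]1C[C@@H]2CC[C@@H]1O2)NS(=O)(=O)N1CCC(CCNC(=O)c2cccc3c2OCCO3)CC1`, gives 13%.

Compound 1 holds the highest of these three numbers, but compound 2 sits within the usual scatter of it, so the two cannot be told apart; only compound 3 lies beyond that scatter, on the weaker side. Compound 4, `Cn1cc(C(=O)NCCC2CCN(S(=O)(=O)NC(=O)NC[C@@H]3C[C@@H]4C=C[C@@H]3C4)CC2)c(=O)n(C)c1=O`, keeps the whole core of compound 1 and differs in one place: a group of 10 heavy atoms (6 carbon, 2 nitrogen, 2 oxygen; one six-membered aromatic ring with 2 hetero atoms) in place of a group of 6 heavy atoms (4 carbon, 1 nitrogen, 1 sulfur; one five-membered aromatic ring with 2 hetero atoms), on a carbonyl carbon. Among the compounds with values here, no measured pair shows what such a swap does, so the step is expected to stay within the scatter, if anything slightly downward. Compound 4 is therefore estimated at 22%, between 8% and 38%, an expected step of a number 3 percentage points lower from compound 1 to compound 4 (within the scatter).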

Compound 4, a percentage reported as activity, at one dose (the size of the read-out at that dose, not a potency): 32%
Beside the measured number, compound 4's estimate is 10 percentage points below it; the range from low to high includes it.
By their numbers in this assay, from the lowest: compounds 3, 2, 1 and 4 (each within the scatter of the next, the first and the last beyond it).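

In this assay, putting the larger six-membered aromatic ring on the carbonyl carbon in place of 4-methyl-1,3-thiazol-5-yl gives a number 7 percentage points higher from compound 1 to compound 4 (within the scatter). This first pair differing in one place shows that the position accepts a group of 10 heavy atoms instead of one of 6 with no readable loss at this dose. No supporting data explain this result. A single pair cannot show what a plain phenyl ring or a small methyl group would give on this carbonyl carbon. Going by these compounds, whether the same swap holds with a cyclohexyl group at the molecule's other end also stays open.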